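The source may hold more compounds than are shown below. What is called first, only, known or untested is meant among the compounds shown, and "the series" means these compounds.

Going by the values given here, in a physicochemical assay for lipophilicity, at pH 7.4 (a lower number here means a more polar compound, a higher number a more lipophilic compound), compound 1 `Cc1[nH]ncc1-c1nnc(-c2ccc(OC(C)C)c(Cl)c2)s1` gives 5.45, the highest of the three numbers measured so far. Compound 2 `CC(C)Oc1ccc(-c2nnc(-n3ncc4c3CCN(CCC(=O)O)C4)s2)cc1Cl` gives 3.54 and compound 3 `Cc1c(-c2nnc(-c3ccc(OC(C)C)c(Cl)c3)s2)cnn1CCC(=O)O` gives 3.16, both lower than compound 1 by more than the usual scatter.

Compound 4 `CC(C)Oc1ccc(-c2nnc(-c3cn[nH]c3)s2)cc1Cl` has not yet been measured. It differs from compound 1 in one place: hydrogen in place of methyl on an aromatic carbon. In words, this is hydrogen in place of methyl on an aromatic carbon, which turns 5-methyl-1H-pyrazol-4-yl into 1H-pyrazol-4-yl.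

Among the compounds with values here, only one measured step can be set beside this change: a number 2.29 log units lower from compound 1 to compound 3 (beyond the scatter). That large step comes from 2-carboxyethyl in place of hydrogen on an aromatic nitrogen, a different change in a different place, so it bears only loosely on compound 4. It shows how far this assay can move in this series, but it does not give a size for losing a methyl. Here only a methyl leaves and only a hydrogen enters, so a much smaller shift is expected, towards a lower number.

The expected result is a number 0.40 log units lower from compound 1 to compound 4 (beyond the scatter), a small step. For compound 4 the estimated value is 5.05, with an expected range from 4.6 to 5.4.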

Compound 4, distribution coefficient: 5
Beside the measured number, compound 4's estimate is 0.05 log units above it; the measured number falls inside the stated range.
By their numbers in this assay, from the lowest: compound 3; then compound 2; then compound 4; then compound 1.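

In this assay, the methyl on this aromatic carbon of the five-membered ring has a measurable effect: hydrogen in its place, which turns 5-methyl-1H-pyrazol-4-yl into 1H-pyrazol-4-yl, gives a number 0.45 log units lower from compound 1 to compound 4 (beyond the scatter) as a modest step. Going by these compounds alone, the only earlier step of this kind was a number 2.29 log units lower from compound 1 to compound 3 (beyond the scatter) on adding 2-carboxyethyl at an aromatic nitrogen, so the new result adds a second place and shows that this assay also moves, though much less, when a single carbon leaves. No independent evidence bears on why the step has this size.

The compounds shown leave open how this assay would read with another group on this same aromatic carbon, such as an ethyl group, a trifluoromethyl group or an amine. They also leave open whether hydrogen in place of methyl would give a step of similar size in compound 3, which keeps the methyl and also carries 2-carboxyethyl on the aromatic nitrogen.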